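A few compounds are considered here, and "the series" means these few. Any claim that something is new, unique, unknown or untested is made for them only; others in the source may bear on it.

The series shares one urea core and differs only in the aryl group carried on an aromatic nitrogen of the triazole. Compound 1 `Cc1ccccc1-n1cc(COc2cccc(NC(=O)Nc3ccc(Cl)c(C(F)(F)F)c3)c2)nn1` gives 3440 nM in a functional assay on HepG2 cells (Homo sapiens) for inhibition, read by MTT assay, with a stated time of 72 h; on this read-out lower numbers stand for stronger inhibition and higher numbers for weaker inhibition. Compound 2 `O=C(Nc1cccc(OCc2cn(-c3cccc(F)c3)nn2)c1)Nc1ccc(Cl)c(C(F)(F)F)c1` gives 2120 nM in this assay, and compound 3 `O=C(Nc1cccc(OCc2cn(-c3cccc(C(F)(F)F)c3)nn2)c1)Nc1ccc(Cl)c(C(F)(F)F)c1` gives 1270 nM. Among these three numbers compound 3 holds the lowest, yet its separation from compound 2 is a 1.7-fold lower number from compound 2 to compound 3 (0.22 log units; within the scatter), while against compound 1 it is a 2.7-fold lower number from compound 1 to compound 3 (0.43 log units; beyond the scatter); the remaining step is a 1.6-fold lower number from compound 1 to compound 2 (0.21 log units; within the scatter).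

Compound 4 `O=C(Nc1cccc(OCc2cn(-c3ccc(C(F)(F)F)cc3)nn2)c1)Nc1ccc(Cl)c(C(F)(F)F)c1` is the positional isomer of compound 3: the change is 4-(trifluoromethyl)phenyl in place of 3-(trifluoromethyl)phenyl on an aromatic nitrogen. None of the three measured steps moves a group around the same ring; each exchanges one aryl substituent for a different one, and together they cover only a narrow span of values in this assay. Among the measured compounds shown here, there is thus no measured step that bears directly on shifting the trifluoromethyl from one position to another. On that footing the expected movement from compound 3 to compound 4 is estimated as a 1.1-fold higher number from compound 3 to compound 4 (0.04 log units; within the scatter), that is, no change beyond the scatter. Compound 4 is therefore expected to give about 1400 nM in this assay, within a range from 500 nM to 4000 nM.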

Compound 4, half-maximal inhibitory concentration: 1800 nM
Compound 4: the middle estimate sits 1.3-fold (0.11 log units) below what was measured, and the stated range covers the measured number.
By their numbers in this assay, from the lowest: compounds 3, 4, 2 and 1 (each within the scatter of the next, the first and the last beyond it).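

Compound 4 gives the first measured case of a group moving around the same ring: in this assay, 4-(trifluoromethyl)phenyl in place of 3-(trifluoromethyl)phenyl on the aromatic nitrogen gives a 1.4-fold higher number from compound 3 to compound 4 (0.15 log units; within the scatter) and so does not separate the two placements of the trifluoromethyl at this position. The other two new steps also stay inside the scatter, with a 1.2-fold lower number from compound 2 to compound 4 (0.07 log units; within the scatter) against the 3-fluorophenyl analogue and a 1.9-fold lower number from compound 1 to compound 4 (0.28 log units; within the scatter) against the 2-methylphenyl analogue, so the separation from compound 1 that is printed for compound 3 does not carry over to compound 4 and the 4-(trifluoromethyl)phenyl group cannot be told apart from any of the other aryl groups in this series. Nothing available here gives a reason for these small steps or for the difference between the two isomers.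

The compounds shown leave open whether the 2-(trifluoromethyl)phenyl isomer would complete this picture and whether an amine or a carboxylic acid on the same phenyl ring would move the number further than these groups do. They also leave open what a simple alkyl chain, such as a longer chain carried on the aromatic nitrogen in place of the phenyl ring, would give in this assay.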